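A methyl group on a compound known only by a limit

A few compounds are considered here, and "the series" means these few. Any claim that something is new, unique, unknown or untested is made for them only; others in the source may bear on it.

- compound 1 (`Cc1ccc(-c2c(CNC(C)(C)C)c(C(=O)O)nn2-c2ccccc2)cc1`): a limit (> 688000 nM)
- compound 2 (`CC(C)(C)NCc1c(C(=O)O)nn(-c2ccc(Cl)cc2)c1-c1ccccc1`): a limit (> 652000 nM)

Both compounds were tested for growth inhibition (a functional assay on HT-29 cells (Homo sapiens) for inhibition, read by sulforhodamine B assay, with a stated time of 48 h; a higher number here means a weaker inhibitor of growth, a lower number a stronger inhibitor of growth), and neither gave a number. Compound 2 stands on a limit alone (> 652000 nM). Compound 1 also stands on a limit alone (> 688000 nM). Among the measured compounds shown here, the two compounds differ in more than one place, and no measured step links them, so the data give no size for any single change.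

Compound 3 (`Cc1ccc(-c2c(CNC(C)(C)C)c(C(=O)O)nn2-c2ccc(Cl)cc2)cc1`) follows from compound 2 by one change (methyl in place of hydrogen on an aromatic carbon): methyl in place of hydrogen on an aromatic carbon, which turns phenyl into 4-methylphenyl. Compound 1 carries the same 4-methylphenyl group, and its result is again a limit (> 688000 nM). On that basis compound 3 is expected to report a limit too, rather than a number.

The expected step is none beyond the scatter (an at least 1.0-fold lower number from compound 2 to compound 3 (0.02 log units; that floor lies within the scatter)). For compound 3 the estimated value is (620000 nM), with an expected range of (250000 nM to 800000 nM).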

Compound 3, concentration for 50% growth inhibition: > 629000 nM
Compound 3: only a limit was reported (the forecaster's own chance of this, stated with the estimate: 85%); middle value at least 1.0-fold (0.00 log units) away from the limit.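

In this assay compound 3 gives > 629000 nM, which is a limit and not a number. Its steps from compound 2 and from compound 1 cannot be read. The compounds shown leave open what effect, if any, the methyl or chloro change has on growth inhibition, as none of the three has a measured number.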